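From Methyl to Chloro: What to Expect for Compound 3

The compounds below may be only part of what the source reports. "The series", "measured", "known", "first", "only" and "open" are said of these compounds alone.

Compound 2 `COc1ccccc1N1CCN(CC2Nc3cc(C)ccc3S(=O)(=O)N2)CC1` was tested in a functional assay on spleen for antagonist activity at Alpha-1B adrenergic receptor (Rattus norvegicus) (on this read-out lower numbers stand for lower potency and higher numbers for higher potency (the scale is a negative logarithm)), where compound 2 gives 6.24. Among the measured compounds shown here, the only other measured compound, compound 1 `COc1ccccc1N1CCN(CC2Nc3ccccc3S(=O)(=O)N2)CC1`, gives 5.97 in this assay, and the step of a number 0.27 log units higher from compound 1 to compound 2 (within the scatter) lies within the scatter, so the two cannot be told apart on these numbers. Compound 3 `COc1ccccc1N1CCN(CC2Nc3cc(Cl)ccc3S(=O)(=O)N2)CC1` has not yet been measured; it differs from compound 2 by chloro in place of methyl on an aromatic carbon. Just one measured step bears on this change: the step of a number 0.27 log units higher from compound 1 to compound 2 (within the scatter), where methyl in place of hydrogen on the same aromatic carbon gave no shift beyond the scatter. Since chloro and methyl are single heavy atoms without donors or acceptors, the expectation is a step of a number 0.06 log units higher from compound 2 to compound 3 (within the scatter), none beyond the scatter. Compound 3 is therefore estimated at 6.3, with a range from 5.8 to 6.8.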

Compound 3, negative logarithm of the antagonist equilibrium constant: 5.09
Compound 3: the middle estimate sits 1.21 log units above what was measured; the whole stated range lies above it.
By their numbers in this assay, from the lowest: compound 3; then compounds 1 and 2 (each within the scatter of the next).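

This position on the shared core is not indifferent to what sits on it, something the step from hydrogen to methyl, which stayed within the scatter, could not show. In this assay chloro in place of methyl gives a number 1.15 log units lower from compound 2 to compound 3 (beyond the scatter) and chloro in place of hydrogen gives a number 0.88 log units lower from compound 1 to compound 3 (beyond the scatter), so chloro stands apart from both, even though chloro and methyl match in heavy-atom count and in having no hydrogen-bond donors or acceptors. Nothing available here accounts for this loss of potency.

From the compounds shown here alone, whether the loss is peculiar to chloro or is shared by other groups on this aromatic carbon remains open. Fluoro, bromo or an amine at the same place would help to show how far it extends.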